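The source may hold more compounds than are shown below. What is called first, only, known or untested is meant among the compounds shown, and "the series" means these compounds.

Working notes on the series. In an assay on isolated protein for inhibition of lysosomal alpha-glucosidase (Rattus norvegicus), read by colorimetric assay (a higher number here means a weaker inhibitor, a lower number a stronger inhibitor), compound 1 `Cc1ccc(S(=O)(=O)Nc2ccc3c(c2)C(=O)N(CCNc2ccc(O)c(O)c2)C3=O)cc1` gives 28800 nM, the lowest of the two numbers in hand. Compound 2 `Cc1ccc(S(=O)(=O)Nc2ccc3c(c2)C(=O)N(CCNc2ccccc2)C3=O)cc1` gives 99600 nM in this assay; the step of a 3.5-fold higher number from compound 1 to compound 2 (0.54 log units; beyond the scatter) shows that the change to phenyl in place of 3,4-dihydroxyphenyl on an amine nitrogen moves the number up. Compound 3 `Cc1ccc(S(=O)(=O)Nc2ccc3c(c2)C(=O)N(Cc2ccc(Cl)c(Cl)c2)C3=O)cc1` has not yet been measured. It differs from compound 1 by a group of 8 heavy atoms (6 carbon, 2 chlorine; one six-membered aromatic ring of carbon only) in place of a group of 10 heavy atoms (7 carbon, 1 nitrogen, 2 oxygen; one six-membered aromatic ring of carbon only), on a saturated chain carbon bound to an amide-type nitrogen in a ring. Within the data shown here, only the step from compound 1 to compound 2 bears on this, and it removes the two hydroxyl groups that compound 3 also lacks, while compound 3 additionally loses the amine nitrogen and part of the chain. A step in this assay of at least the size of a 3.5-fold higher number from compound 1 to compound 2 (0.54 log units; beyond the scatter) is therefore expected, in the weakening direction. For compound 3 the estimate in this assay is a 3.1-fold higher number from compound 1 to compound 3 (0.49 log units; beyond the scatter), giving an expected value of 90000 nM with a range from 25000 nM to 300000 nM.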

Compound 3, half-maximal inhibitory concentration: 122000 nM
The estimate for compound 3 lay 1.4-fold (0.13 log units) below the measured number, within the range that was stated.
By their numbers in this assay, from the lowest: compound 1; then compounds 2 and 3 (each within the scatter of the next).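

On the saturated chain carbon bound to an amide-type nitrogen in a ring, 3,4-dichlorophenyl gives in this assay a 4.2-fold higher number from compound 1 to compound 3 (0.63 log units; beyond the scatter) and so, like the loss of the two hydroxyl groups, leaves the number beyond the scatter of compound 1. Set against the anilinomethyl group, the same change gives a 1.2-fold higher number from compound 2 to compound 3 (0.09 log units; within the scatter) and separates neither compound, so among these three only compound 1, with its 3,4-dihydroxyphenyl end, stands apart. No measurement in hand gives a reason for this result.

Still open, on these data alone, is whether one hydroxyl group suffices, as a 3-hydroxyphenyl or 4-hydroxyphenyl end would show on the same chain. Also open, as far as these compounds go, is whether 3,4-dihydroxyphenyl set directly on the chain carbon, without the amine nitrogen, keeps the lower number of compound 1.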